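The source may report more compounds than this note shows. Statements on the series, on what has been measured and on what is new or still open speak of the compounds shown alone.

Measured compounds in the series:
- compound 1, `CCOC(=O)c1ccc(NC(=O)N2CC2C#N)cc1`: 5800 nM
- compound 2, `N#CC1CN1C(=O)NC1CCCCC1`: 35000 nM
- compound 3, `CC(C)(C)NC(=O)N1CC1C#N`: 418000 nM

All three share the cyanoaziridine urea core and differ only in the group on the urea nitrogen. In a functional assay on A-375 cells (Homo sapiens) for inhibition (a higher number here means a weaker inhibitor, a lower number a stronger inhibitor), compound 3 gives 418000 nM, the highest number of the three; compound 2 stands nearer to it and compound 1 furthest from it, both gaps beyond the scatter. Going by the values given here, no single-point steps among the measured compounds are available, so the effect of changing the group on this nitrogen can only be read from the three values side by side.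

Compound 4, `CCNC(=O)N1CC1C#N`, has not yet been measured. It differs from compound 3 as follows: ethyl in place of tert-butyl on an amide-type nitrogen. The measured set offers no direct comparison of two alkyl groups of different size on this nitrogen, so the direction of the step is open. Since compound 2 with a larger alkyl group gives 35000 nM, a lower number than compound 3, a move toward a lower number is expected, but with wide uncertainty. The expected step is a 3.5-fold lower number from compound 3 to compound 4 (0.54 log units; beyond the scatter). Compound 4 is therefore estimated at 120000 nM in this assay, with a range from 20000 nM to 700000 nM.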

Compound 4, half-maximal inhibitory concentration: 36000 nM
The estimate for compound 4 lay 3.3-fold (0.52 log units) above the measured number; measured number inside the range.
By their numbers in this assay, from the lowest: compound 1; then compounds 2 and 4 (each within the scatter of the next); then compound 3.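

In this assay, going by these compounds alone, the first direct comparison of two alkyl groups on this amide-type nitrogen shows that the choice of group alone can carry a large change: ethyl in place of tert-butyl gives a 12-fold lower number from compound 3 to compound 4 (1.06 log units; beyond the scatter), a step beyond the scatter. Compound 4 at 36000 nM and compound 2 at 35000 nM lie within the scatter of each other, so the high number of compound 3 stands apart from both. A rule that fewer carbons on this nitrogen give a lower number would fit compound 3 and compound 4, but compound 2, with its larger cyclohexyl group, goes against it.

Open, from the compounds shown here alone, is how a methyl group, a longer chain such as n-butyl or a phenyl ring without the ester would compare on this nitrogen. No measurement shown here bears on the large step.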